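The source may hold more compounds than are shown below. What is called first, only, known or untested is meant among the compounds shown, and "the series" means these compounds.

Measured so far:
compound 1 `O=C1C(=O)N(CN2CCN(c3ccnc4cc(Cl)ccc34)CC2)c2cccc(Br)c21` gives 65600 nM in an ADME assay on MCF-10A cells (Homo sapiens) for cytotoxicity, read by sulforhodamine B assay, with a stated time of 48 h; on this read-out lower numbers stand for stronger inhibition of growth and higher numbers for weaker inhibition of growth
compound 2 `O=C1C(=O)N(CN2CCN(c3ccnc4cc(C(F)(F)F)ccc34)CC2)c2cc(Cl)ccc21` gives 32800 nM in this assay
compound 3 `NC(=S)N/N=C1/C(=O)N(CN2CCN(c3ccnc4cc(Cl)ccc34)CC2)c2cccc(Cl)c21` gives 19800 nM in this assay

Of these three numbers, the value of compound 3 is the lowest. Compound 2 stands within the scatter of compound 3, so the two cannot be told apart; compound 1 lies beyond the scatter of compound 3 and gives the weaker growth inhibition of the pair. Compound 1 and compound 3 differ in more than one place, so no single change can be credited for that gap.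

Compound 4 `NC(=S)N/N=C1/C(=O)N(CN2CCN(c3ccnc4cc(Cl)ccc34)CC2)c2cccc(Br)c21` has not yet been measured in this assay. It differs from compound 3 in one place: bromo in place of chloro on an aromatic carbon – that is, bromo in place of chloro on an aromatic carbon. Among the measured compounds shown here, no measured pair shows this exchange on its own, so no step for it is known here. Swapping one halogen for the next heavier one at the same place is a small change, and the expectation is a step of a 1.1-fold higher number from compound 3 to compound 4 (0.05 log units; within the scatter), that is, no change beyond the scatter. Compound 4 is therefore estimated at 22000 nM, within a range from 9000 nM to 55000 nM.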

Compound 4, concentration for 50% growth inhibition: 29400 nM
Estimate against measurement, compound 4: 1.3-fold (0.13 log units) below; measured number inside the range.
By their numbers in this assay, from the lowest: compounds 3, 4, 2 and 1 (each within the scatter of the next, the first and the last beyond it).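

Among the compounds shown here, compound 3 and compound 4 are the first pair here that differ in one place only, so the exchange of chloro for bromo on an aromatic carbon can be read on its own. In this assay, that exchange gives a 1.5-fold higher number from compound 3 to compound 4 (0.17 log units; within the scatter), so at this place, on a six-membered aromatic ring of carbon only that is part of a fused or bridged system of two rings, the two halogens cannot be told apart by their growth inhibition in these cells. Nothing measured here says why the exchange gives a step of this size.

This single pair speaks for one exchange at one place, with the rest of compound 3 held fixed, so it cannot show whether chloro and bromo would also match elsewhere on that ring or in another compound. As far as these compounds go, whether fluoro, a methoxy group, an amine or a carboxylic acid at the same place would stay within the scatter of these two halogens or move the number beyond it remains open.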